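From 4-methylphenyl to 4-methylbenzyl on sulfur

The compounds below may be only part of what the source reports. "The series", "measured", "known", "first", "only" and "open" are said of these compounds alone.

In a functional assay on DU-145 cells (Homo sapiens) for inhibition, read by trypan blue exclusion, with a stated time of 96 h (on this read-out higher numbers stand for weaker inhibition of growth and lower numbers for stronger inhibition of growth), compound 3 (`Cc1ccc(S/C(=C/c2sccc2C)C(=O)c2ccc(Cl)cc2)cc1`) gives 50000 nM. Compound 1 (`Cc1ccsc1/C=C(/SCc1ccc(Cl)c(Cl)c1)C(=O)c1ccc(Cl)cc1`) gives 50000 nM, level with compound 3, and together they hold the highest of the three numbers measured. Compound 2 (`Cc1ccc(CS/C(=C/c2c[nH]c3ccc(Br)cc23)C(=O)c2ccc(Cl)cc2)cc1`) gives 1000 nM, a much lower number and beyond the scatter from both.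

Compound 4 (`Cc1ccc(CS/C(=C/c2sccc2C)C(=O)c2ccc(Cl)cc2)cc1`) has 4-methylbenzyl in place of 4-methylphenyl on a sulfur. Among the compounds with values here, the one measured step at this sulfur, no change at the digits printed from compound 1 to compound 3 (within the scatter), exchanged 3,4-dichlorobenzyl for 4-methylphenyl. Compound 2 also carries 4-methylbenzyl on a sulfur, but it differs from compound 4 elsewhere, so the data do not show how much of its lower number goes with that group. It leaves only a modest allowance toward lower numbers. No step beyond the scatter is therefore expected in this assay, and the estimated move is a 1.3-fold lower number from compound 3 to compound 4 (0.10 log units; within the scatter). For compound 4 the expected value is 40000 nM, with an estimated range of 12000 nM to 70000 nM.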

Compound 4, concentration for 50% growth inhibition: 10000 nM
Compound 4: the middle estimate sits 4.0-fold (0.60 log units) above what was measured; the measured number lies below the stated range.
By their numbers in this assay, from the lowest: compound 2; then compound 4; then compounds 1 and 3 (each within the scatter of the next).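

In this assay, 4-methylbenzyl in place of 4-methylphenyl on a sulfur gives a 5.0-fold lower number from compound 3 to compound 4 (0.70 log units; beyond the scatter) and so shows that this position can respond, which the earlier step of no change at the digits printed from compound 1 to compound 3 (within the scatter) had not shown. Among the benzyl groups on this sulfur the ring substituents also count, since 4-methylphenyl in place of 3,4-dichlorophenyl on a saturated chain carbon bound to a sulfur gives a 5.0-fold lower number from compound 1 to compound 4 (0.70 log units; beyond the scatter). With 4-methylbenzyl held constant, 3-methylthiophen-2-yl in place of 5-bromo-1H-indol-3-yl gives a 10-fold higher number from compound 2 to compound 4 (1.00 log units; beyond the scatter), so the sulfur group alone does not set the low number of compound 2.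

Nothing at hand explains these steps. From the compounds shown here alone, whether a longer chain on the sulfur, or an amine in place of the methyl on the 4-methylbenzyl ring, would lower the number further remains open.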